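The source may hold more compounds than are shown below. What is called first, only, known or untested is meant among the compounds shown, and "the series" means these compounds.

Measured so far in a functional assay on PC-3 cells (Homo sapiens) for cytotoxicity, read by MTT assay, with a stated time of 72 h; a higher number here means a weaker inhibitor, a lower number a stronger inhibitor:
compound 1, `FC(F)(F)c1ccc(CSc2nc(N3CCCCC3)c3ccccc3n2)cc1`, gives 25500 nM;
compound 2, `FC(F)(F)c1ccc(CSc2nc(Nc3ccc(Cl)cc3)c3ccccc3n2)cc1`, gives 7110 nM;
compound 3, `FC(F)(F)c1ccc(CSc2nc(Nc3ccc(C(F)(F)F)cc3)c3ccccc3n2)cc1`, gives 7880 nM.

Compound 3 sits second highest of the three numbers. Its closest neighbour is compound 2, with a 1.1-fold higher number from compound 2 to compound 3 (0.04 log units; within the scatter); the gap to compound 1 is wider, with a 3.2-fold lower number from compound 1 to compound 3 (0.51 log units; beyond the scatter). Both steps from compound 1, the other being a 3.6-fold lower number from compound 1 to compound 2 (0.55 log units; beyond the scatter), come from replacing a piperidin-1-yl group with a substituted phenylamino group.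

Compound 4, `COc1ccc(Nc2nc(SCc3ccc(C(F)(F)F)cc3)nc3ccccc23)cc1`, keeps the phenylamino group and changes only the substituent on it: methoxy in place of trifluoromethyl on an aromatic carbon. For the measured compounds named here, the only measured step that bears on this kind of change is the swap of chloro for trifluoromethyl, a 1.1-fold higher number from compound 2 to compound 3 (0.04 log units; within the scatter), which stayed within the scatter. Nothing measured here involves a methoxy group, so the expectation for compound 4 rests on that single neighbouring step and carries a wide range. The expected step from compound 3 is a 1.1-fold higher number from compound 3 to compound 4 (0.03 log units; within the scatter), that is, no change beyond the scatter. For compound 4 in this assay the estimate is 8500 nM, between 3000 nM and 25000 nM.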

Compound 4, half-maximal inhibitory concentration: 16700 nM
Compound 4: the middle estimate sits 2.0-fold (0.29 log units) below what was measured, within the range that was stated.
By their numbers in this assay, from the lowest: compounds 2 and 3 (each within the scatter of the next); then compounds 4 and 1 (each within the scatter of the next).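

Unlike the swap of chloro for trifluoromethyl, which stayed within the scatter, placing methoxy on this same aromatic carbon does shift the result in this assay: there is a 2.1-fold higher number from compound 3 to compound 4 (0.33 log units; beyond the scatter), and a 2.3-fold higher number from compound 2 to compound 4 (0.37 log units; beyond the scatter). The substituent on the phenylamino group therefore matters here, and the earlier gain over piperidin-1-yl does not hold for every phenylamino group, since compound 4 goes against it with a 1.5-fold lower number from compound 1 to compound 4 (0.18 log units; within the scatter). No measurement shown explains why methoxy parts from chloro and trifluoromethyl.

Still open, as far as these compounds go, is whether a hydroxyl group, an amine or a nitrile at this place would stay with chloro and trifluoromethyl or fall with methoxy. Also open, from the compounds shown here alone, is what a phenylamino group carrying only hydrogen would give, the baseline against which each of these three groups could be judged.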